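The compounds below may be only part of what the source reports. "The series", "measured", "known", "first", "only" and "open" are said of these compounds alone.

Series notes. In an ADME assay on Raji cells (Homo sapiens) for cytotoxicity, read by CellTiter-Glo and resazurin assay, with a stated time of 72 h (a higher number here means that more compound is needed for the effect, a lower number that less compound is needed), compound 1 `CC(C)COc1cccc(-c2ccc(C(=O)N(Cc3cccc(OCCCCCC(=O)O)c3)C(C)C)cc2)c1` returns only a limit, > 26000 nM. Compound 2 `CCOC(=O)CCCCCOc1cccc(CN(C(=O)c2ccc(-c3cccnc3)cc2)C(C)C)c1` likewise returns only a limit in this assay, > 26000 nM. Both measured results sit at the limit of > 26000 nM in this assay, at which 2 of the 2 values shown sit, so compound 2 stands where every measured compound of the set stands, with no number below the limit for comparison. Compound 3 `CCOC(=O)CCCCCOc1cccc(CN(C(=O)c2ccc(-c3cccc(-c4nnc(C)o4)c3)cc2)C(C)C)c1` carries the change (3-(5-methyl-1,3,4-oxadiazol-2-yl)phenyl in place of pyridin-3-yl on an aromatic carbon). Within the data shown here, no measured step is available, and in this assay no shift beyond the scatter is expected from compound 2 to compound 3. Compound 3 is expected at 26000 nM, between 9000 nM and 70000 nM. The estimated step of a number no higher from compound 2 to compound 3 (the limit leaves the size open) means no movement.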

Compound 3, half-maximal effective concentration: > 26000 nM
Compound 3: only a limit was reported (the forecaster's own chance of this, stated with the estimate: 70%); the middle value lies on the limit itself.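

Compound 2 and compound 3 both return only limits in this assay, so no step can be read between them. The compounds shown leave open at what concentration any of them reaches half-maximal effect, since all rest on one limit: the limit of > 26000 nM in this assay, at which 3 of the 3 values shown sit.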